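Thiophene for pyrazole on the chlorinated benzyl arm

The compounds below may be only part of what the source reports. "The series", "measured", "known", "first", "only" and "open" are said of these compounds alone.

Within the data shown here, compound 2 `Cn1nc2c(=O)n(CC3(O)CCN(Cc4ccc(-n5cccn5)cc4Cl)CC3)cnc2c1-c1ccc(CN)cc1` gives 233 nM in an assay on isolated protein for inhibition of ubiquitin carboxyl-terminal hydrolase 7 (Homo sapiens), with stated times of 30 min and 2 h (a higher number here means a weaker inhibitor, a lower number a stronger inhibitor), the lowest of the two numbers so far. Its nearest neighbour is compound 1 `Cn1nc2c(=O)n(CC3(O)CCN(Cc4ccc(C5CCCO5)cc4Cl)CC3)cnc2c1-c1ccc(CN)cc1`, which in this assay gives 3820 nM. Among the measured compounds shown here, the one step in hand, a 16-fold lower number from compound 1 to compound 2 (1.21 log units; beyond the scatter), shows that the group on this aromatic carbon moves the read-out strongly, there going from a saturated to an aromatic five-membered ring. Compound 3 `Cc1ccc(-c2ccc(CN3CCC(O)(Cn4cnc5c(-c6ccc(CN)cc6)n(C)nc5c4=O)CC3)c(Cl)c2)s1` carries 5-methylthiophen-2-yl in place of 1H-pyrazol-1-yl on an aromatic carbon. For the measured compounds named here, that measured step bears on the new one only loosely, since here one five-membered aromatic ring replaces another, and there is no measured pair on this series that exchanges two aromatic rings at this position. A movement in this assay smaller than the measured step is expected, with no firm direction, leaning toward a somewhat higher number. The expected step is a 1.7-fold higher number from compound 2 to compound 3 (0.23 log units; within the scatter). Compound 3 is estimated at 400 nM, in the range 120 nM to 1500 nM.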

Compound 3, half-maximal inhibitory concentration: 101 nM
Compound 3: middle estimate off by 4.0-fold (0.60 log units), on the high side; measured number outside the range, below it.
By their numbers in this assay, from the lowest: compound 3; then compound 2; then compound 1.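

In this assay the exchange of one five-membered aromatic ring for another is not neutral at this position: there is a 2.3-fold lower number from compound 2 to compound 3 (0.36 log units; beyond the scatter) on going to 5-methylthiophen-2-yl. The aromatic group on this carbon therefore matters in its own right, and the saturated oxolan-2-yl and the 5-methylthiophen-2-yl mark the widest span in the set, with a 38-fold lower number from compound 1 to compound 3 (1.58 log units; beyond the scatter) between them. No measurement in hand gives a reason for the difference between these groups.

The step to compound 3 swaps the ring and adds the methyl at once, so the share of each stays unresolved; unsubstituted thiophen-2-yl would separate them. Also open, from the compounds shown here alone, is how far this position accepts a charged or more polar substituent on the thiophene, such as an aminomethyl group or a carboxylic acid in place of the methyl.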